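The source may hold more compounds than are shown below. What is called first, only, known or untested is meant among the compounds shown, and "the series" means these compounds.

Going by the values given here, in a functional assay on A549 cells (Homo sapiens) for antiproliferative activity, read by MTT assay, with a stated time of 72 h (a higher number here means a weaker inhibitor, a lower number a stronger inhibitor), compound 3 `O=C1COc2ccc(-c3cccc(NS(=O)(=O)c4ccc(F)cc4)c3)cc2N1C1CCCCC1` gives 14500 nM, the only true number in this small set. Compound 1 `COc1cccc(N2C(=O)COc3ccc(-c4cccc(NS(=O)(=O)c5ccc(F)cc5)c4)cc32)c1` gives > 40000 nM, which is a limit of the assay and not a number. Compound 2 `O=C1COc2ccc(-c3cccc(NS(=O)(=O)c4ccc(F)cc4)c3)cc2N1C1CC1` gives > 40000 nM, which is the same limit.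

Compound 4 `O=C1COc2ccc(-c3cccc(NS(=O)(=O)c4ccc(F)cc4)c3)cc2N1c1ccc(F)cc1` keeps the core of compound 3 and changes one group, with 4-fluorophenyl in place of cyclohexyl on an amide-type nitrogen in a ring.

The nearest guide is an at least 2.7-fold lower number from compound 1 to compound 3 (0.44 log units; beyond the scatter), with cyclohexyl in place of 3-methoxyphenyl on that nitrogen. Compound 4 brings a six-membered aromatic ring back to this place, as compound 1 has there, so that step should partly reverse. A second step, an at least 2.7-fold lower number from compound 2 to compound 3 (0.44 log units; beyond the scatter), shows that cyclohexyl also gave the lower number against cyclopropyl, while a step that the two limits leave unreadable from compound 1 to compound 2 gives no size at all.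

The expected change is therefore a modest rise, estimated as a 1.9-fold higher number from compound 3 to compound 4 (0.29 log units; within the scatter). For compound 4 the estimated value is 28000 nM, with an expected range from 11000 nM to 60000 nM.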

Compound 4, half-maximal inhibitory concentration: > 40000 nM
Compound 4 was reported as a limit; the forecaster's own chance of this, stated with the estimate: 45%; at least 1.4-fold (0.15 log units) between middle value and limit.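

Putting 4-fluorophenyl in place of cyclohexyl on the amide-type nitrogen in a ring gives an at least 2.7-fold higher number from compound 3 to compound 4 (0.44 log units; beyond the scatter) in this assay. Going by these compounds alone, a second aromatic ring, this one carrying fluorine, therefore also fails to give a measurable number here, so compound 3 remains the only compound of the four with one. This does not make aromatic rings the sole dividing line, as compound 2, with non-aromatic cyclopropyl, goes against that pattern. The steps from compound 1 and from compound 2 to compound 4 cannot be read, because all three compounds sit at one limit: the limit of > 40000 nM in this assay, at which 3 of the 4 values shown sit.

Still open, on these data alone, is how a longer chain such as hexyl, a benzyl group or a larger carbon ring such as cycloheptyl would behave on this nitrogen. As far as these compounds go, it is also open whether an amine on that group would change the number.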